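The source may report more compounds than this note shows. Statements on the series, on what has been measured and on what is new or still open speak of the compounds shown alone.

Compound 1 `COC(=O)/C=C/c1cccc(N(Cc2cccc(Br)c2)C(=O)C2CCCCC2)c1` and compound 2 `COC(=O)/C=C/c1cccc(N(Cc2ccc(Br)cc2)C(=O)C2CCCCC2)c1` share one core and differ only in where the bromine sits. In an assay on isolated protein with Bile acid receptor (Homo sapiens) as the target (on this read-out higher numbers stand for an effect only at larger amounts of compound and lower numbers for an effect already at smaller amounts), compound 1 reaches only the limit of > 1000 nM. In this assay compound 2 likewise reaches only the limit of > 1000 nM. The step that the two limits leave unreadable from compound 1 to compound 2 is therefore unreadable, as the limit of > 1000 nM in this assay, at which 2 of the 2 values shown sit, shows. Compound 3 `COC(=O)/C=C/c1cccc(N(Cc2ccc(-c3cccc(OC(F)(F)F)c3)cc2)C(=O)C2CCCCC2)c1` differs from compound 2 by 3-(trifluoromethoxy)phenyl in place of bromo on an aromatic carbon. For the measured compounds named here, no measured step bears on this change, and compound 2 stands at a limit, not a number. Compound 3 is expected to take the step of an at least 1.4-fold lower number from compound 2 to compound 3 (0.15 log units; that floor lies within the scatter) toward smaller numbers, an uncertain guess. Compound 3 is estimated at 700 nM, between 120 nM and 4000 nM.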

Compound 3, half-maximal effective concentration: 420 nM
Compound 3: middle estimate off by 1.7-fold (0.22 log units), on the high side; low and high end bracket the measured number.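

In this assay, for the compounds shown here, 3-(trifluoromethoxy)phenyl in place of bromo gives an at least 2.3-fold lower number from compound 2 to compound 3 (0.37 log units; beyond the scatter), the first step that can be read. Compound 3 gives 420 nM, so this aromatic carbon, para to a large group, carries a second aromatic ring and yields a number rather than a limit. The full size of the step stays unknown because compound 2 stands only at a limit: the limit of > 1000 nM in this assay, at which 2 of the 3 values shown sit.

On these data alone, whether the plain phenyl ring would do the same as its trifluoromethoxy-bearing form remains open. So does the effect of a carboxylic acid in place of the methyl ester.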